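Swapping an ester for a dimethoxyphenyl ring on a coumarin-like core

The compounds below may be only part of what the source reports. "The series", "measured", "known", "first", "only" and "open" are said of these compounds alone.

Of the compounds shown here, three sharing one core have been tested in a functional assay on PC-12 cells (Rattus norvegicus) for cytotoxicity, read by MTT assay, with stated times of 3 h and 2 h, tested at 50 uM; a lower number here means a weaker effect, a higher number a stronger effect of the compound at the concentration tested. Compound 1 `COc1ccc(-c2cc3ccc(OCCCCn4cc(CNC(=O)CCCCC5CCSS5)nn4)cc3oc2=O)cc1` gives 55.3%. Compound 2 `CC(=O)c1cc2ccc(OCCCCCn3cc(CNC(=O)CCCCC4CCSS4)nn3)cc2oc1=O` gives 18.2%. Compound 3 `CCOC(=O)c1cc2ccc(OCCCCCn3cc(CNC(=O)CCCCC4CCSS4)nn3)cc2oc1=O` gives 40.7%, which places it second highest of the three numbers: compound 1 lies above it and compound 2 below it, both gaps beyond the scatter.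

Going by the values given here, the only single-point step among the measured compounds is a number 22.5 percentage points higher from compound 2 to compound 3 (beyond the scatter), where an ethoxy replaces a methyl on a carbonyl carbon. Compound 4 `COc1ccc(-c2cc3ccc(OCCCCCn4cc(CNC(=O)CCCCC5CCSS5)nn4)cc3oc2=O)cc1OC` has not yet been measured. Its difference from compound 3 is 3,4-dimethoxyphenyl in place of ethoxycarbonyl on an aromatic carbon. This is a different kind of change from the measured step, so that step gives no direct guide. Among the compounds with values here, compound 1 is the closest relative of compound 4 among the measured compounds, and its value in this assay sits above that of compound 3, though no single step connects compounds 1 and 3.

On this basis compound 4 is expected to rise modestly, by a number 11.3 percentage points higher from compound 3 to compound 4 (beyond the scatter), rather than fall. The estimate for compound 4 in this assay is 52%, within a range from 35% to 68%.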

Compound 4, a percentage reported as activity, at one concentration (the size of the read-out at that concentration, not a potency): 55%
The estimate for compound 4 lay 3 percentage points below the measured number; low and high end bracket the measured number.
By their numbers in this assay, from the lowest: compound 2; then compound 3; then compounds 4 and 1 (each within the scatter of the next).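

Within this assay the replacement of ethoxycarbonyl by 3,4-dimethoxyphenyl gives a number 14.3 percentage points higher from compound 3 to compound 4 (beyond the scatter) and is the first change at this position, on an aromatic carbon two atoms from the ring oxygen, that brings in a ring rather than another carbonyl group. The same entering group in place of acetyl gives a number 36.8 percentage points higher from compound 2 to compound 4 (beyond the scatter) and counts as a large step, whereas the ethoxycarbonyl change counts as a modest one. Among these three compounds, which differ only at this position, the group with a six-membered aromatic ring of carbon only therefore gives the highest number, so the position accepts a larger group without any loss in this read-out. No measurement shown gives a reason for these differences.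

The compounds shown do not separate the contribution of the ring from that of its two methoxy groups, so a plain phenyl would be the informative comparison at this position. Nor do they show what a carboxylic acid or an amine placed here would do, and each number comes from one concentration, so none of them is a potency.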